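Oxolanyl for isopentyl on a triazole nitrogen: cytotoxicity outlook

A few compounds are considered here, and "the series" means these few. Any claim that something is new, unique, unknown or untested is made for them only; others in the source may bear on it.

The series shares one core and varies the group on an aromatic nitrogen of the triazole. Compound 1 `CCCn1nc(C(=O)N[C@H]2COc3ccccc3N(C)C2=S)nc1Cc1ccccc1` carries a propyl there. In a toxicity assay on HT-29 cells (Homo sapiens) for cytotoxicity (on this read-out lower numbers stand for higher toxicity in this test and higher numbers for lower toxicity in this test), compound 1 gives only a limit of the assay, > 100000 nM. Compound 2 `CC(C)n1nc(C(=O)N[C@H]2COc3ccccc3N(C)C2=S)nc1Cc1ccccc1` carries an isopropyl. In this assay compound 2 likewise gives only a limit, > 100000 nM. Compound 3 `CC(C)CCn1nc(C(=O)N[C@H]2COc3ccccc3N(C)C2=S)nc1Cc1ccccc1` carries an isopentyl. In this assay compound 3 again gives only a limit, > 100000 nM. Among the measured compounds shown here, because all three values sit at the same limit, (the limit of > 100000 nM in this assay, at which 3 of the 3 values shown sit), none of the measured steps can be read: a step that the two limits leave unreadable from compound 1 to compound 2, a step that the two limits leave unreadable from compound 1 to compound 3 and a step that the two limits leave unreadable from compound 2 to compound 3 are each unreadable in size. Compound 3 therefore stands exactly where the other two stand, at the limit, with nothing to separate them.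

Compound 4 `CN1C(=S)[C@@H](NC(=O)c2nc(Cc3ccccc3)n(C3CCOC3)n2)COc2ccccc21` is not yet measured. The change from compound 3 is oxolan-3-yl in place of isopentyl on an aromatic nitrogen. The three unreadable steps show that varying this substituent across propyl, isopropyl and isopentyl left every compound at the limit, so a step of readable size is not expected, and the estimate for compound 4 is 150000 nM with a range of 40000 nM to 600000 nM, meaning an expected step that the limit leaves unreadable from compound 3 to compound 4. A further limit is the most likely outcome expected for compound 4.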

Compound 4, half-maximal cytotoxic concentration: > 100000 nM
Compound 4 was reported as a limit (the forecaster's own chance of this, stated with the estimate: 85%); the middle value is on the limit's open side.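

In this assay compound 4 also gives only a limit, so its steps from compound 1, compound 2 and compound 3 cannot be read: the limit of > 100000 nM in this assay, at which 4 of the 4 values shown sit.

The compounds shown leave open whether oxolan-3-yl differs at all from isopentyl, isopropyl or propyl on the aromatic nitrogen in this assay, and at what concentration any of the four compounds would register a cytotoxic effect.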